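The source may hold more compounds than are shown below. What is called first, only, known or untested is meant among the compounds shown, and "the series" means these compounds.

Measured compounds:
Compound 1 `O=C(c1cccc(OC(F)(F)F)c1)N1CCC(N(C2CC2)S(=O)(=O)c2cccc(C(F)(F)F)c2)CC1` gives 78% in an assay on cells for inhibition of Voltage-dependent L-type calcium channel subunit alpha-1C (Homo sapiens), read by FLIPR and calcium flux, tested at 3 uM; a higher number here means a stronger effect of the compound at the concentration tested, a lower number a weaker effect.
Compound 2 `CS(=O)(=O)c1cccc(C(=O)N2CCC(N(C3CC3)S(=O)(=O)c3cccc(C(F)(F)F)c3)CC2)c1` has no result in this assay; its entry there reads "not determined" (no result reported).

Compound 2 therefore stands nowhere on the numbers: no value was obtained for it, so its place cannot be read off, and nothing can be said of how it compares with compound 1. Among the measured compounds shown here, the one measured point is compound 1, which gives 78% in this assay.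

Compound 3 `CN(C)c1cccc(C(=O)N2CCC(N(C3CC3)S(=O)(=O)c3cccc(C(F)(F)F)c3)CC2)c1` differs from compound 2 in one place: dimethylamino in place of methylsulfonyl on an aromatic carbon. For the measured compounds named here, with compound 2 unmeasured, no step between the two can be sized or given a direction in this assay; the expectation for compound 3 rests on the shared core and on compound 1 alone, and any difference from compound 2 is taken to lie within the scatter. Compound 3 is estimated to give 60% in this assay, with a range from 30% to 90%.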

Compound 3, a percentage reported as inhibition, at one concentration (the size of the read-out at that concentration, not a potency): 63%
Beside the measured number, compound 3's estimate is 3 percentage points below it; measured number inside the range.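

Among the compounds shown here, compound 3 gives this position on the aromatic ring a second measured group, so a change there can be sized for the first time: in this assay, dimethylamino in place of trifluoromethoxy gives a number 15 percentage points lower from compound 1 to compound 3 (beyond the scatter). The read-out at this position therefore responds to the group it carries, although with dimethylamino the effect is reduced rather than lost, as compound 3 still gives 63%; the step from compound 2 to compound 3 cannot be read, as compound 2 has no result. Nothing available accounts for this difference.

Going by these compounds, it remains open where methylsulfonyl at this position would stand relative to dimethylamino and trifluoromethoxy in this assay. On these data alone, it is also open how a carboxylic acid, a methoxy group or a chlorine atom in that place would read.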